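A few compounds are considered here, and "the series" means these few. Any claim that something is new, unique, unknown or untested is made for them only; others in the source may bear on it.

Working notes on the urea series.

Three compounds have numbers in an ADME assay on the whole organism with Oryza sativa as the target, tested at 0.1 uM; a higher number here means a weaker effect of the compound at the concentration tested, a lower number a stronger effect. Compound 1, `Cc1cccc(NC(=O)N[C@@H](C)c2ccccc2)c1`, gives 99% in this assay. Compound 2, `Cc1ccc(NC(=O)N[C@@H](C)c2ccccc2)cc1`, gives 100% in this assay, and compound 3, `CCc1ccc(NC(=O)N[C@H](C)c2ccccc2)cc1`, gives 95% in this assay. Compound 1 sits with the other two: its number is within the usual scatter of both that of compound 2 and that of compound 3, so no order among the three can be read from these values, and the whole set points to little effect at the concentration tested.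

Compound 4, `CC(C)c1cccc(NC(=O)N[C@@H](C)c2ccccc2)c1`, has not yet been measured in this assay. Set against compound 1 it shows one change: isopropyl in place of methyl on an aromatic carbon. Among the measured compounds shown here, no pair of measured compounds carries a step of this kind, so nothing measured speaks to its size. Given that compound 1 gives 99% and the other two lie with it, the step from compound 1 to compound 4 is expected to be none beyond the scatter, a number 2 percentage points lower from compound 1 to compound 4 (within the scatter). Compound 4 is therefore estimated at 97% in this assay, within 88% to 100%.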

Compound 4, a percentage reported as activity, at one concentration (the size of the read-out at that concentration, not a potency): 95%
The estimate for compound 4 lay 2 percentage points above the measured number, within the range that was stated.
By their numbers in this assay, from the lowest: compounds 3, 4, 1 and 2 (each within the scatter of the next).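

In this assay, the step of isopropyl in place of methyl on an aromatic carbon, meta to a large group, is a number 4 percentage points lower from compound 1 to compound 4 (within the scatter), the first step measured at this position. Going from 1 heavy atom to 3 heavy atoms, with no hydrogen-bond donor or acceptor on either side, therefore leaves the read-out unchanged within the scatter, and compound 4 at 95% still points to little effect at the concentration tested. No measurement at hand bears on this result.

As far as these compounds go, whether an amine, a carboxylic acid or a longer chain at this position would move the number beyond the scatter remains open. Also open, from the compounds shown here alone, is whether any change to the shared core, rather than to this alkyl group, would produce a stronger effect at this concentration.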